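The compounds below may be only part of what the source reports. "The series", "measured", "known", "first", "only" and "open" are said of these compounds alone.

Measured compounds in a functional assay on A-375 cells (Homo sapiens) for antiproliferative activity, read by CCK-8 assay, with a stated time of 72 h, tested at 8 uM; a lower number here means a weaker effect, a higher number a stronger effect of the compound at the concentration tested:
compound 1 `Nc1ccccc1NC(=O)c1ccc(CSC(=S)N2CCc3cc(Cl)ccc32)cc1`: 82.3%
compound 2 `CC1CCN(C(=S)SCc2ccc(C(=O)Nc3ccccc3N)cc2)CC1`: 87.4%
compound 3 `CN1CCN(C(=S)SCc2ccc(C(=O)Nc3ccccc3N)cc2)CC1`: 91.6%

Compound 1 stands lowest of the three numbers in this assay, but the gaps to compound 2, a number 5.1 percentage points higher from compound 1 to compound 2 (within the scatter), and to compound 3, a number 9.3 percentage points higher from compound 1 to compound 3 (within the scatter), lie within the scatter, so the three cannot be ordered. Compound 4 `COC(=O)c1ccc2c(c1)CCN2C(=S)SCc1ccc(C(=O)Nc2ccccc2N)cc1` differs from compound 1 in one place: methoxycarbonyl in place of chloro on an aromatic carbon. For the measured compounds named here, none of the measured steps bears on this change; each of them replaces the whole group on the thiocarbonyl carbon and leaves the fused ring untouched. The change in compound 4 is thus without precedent in the series, and no step beyond the scatter is expected. Compound 4 is estimated at 82%, with a range from 65% to 93%. The step of a number 0.3 percentage points lower from compound 1 to compound 4 (within the scatter) is expected to remain within the scatter.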

Compound 4, a percentage reported as inhibition, at one concentration (the size of the read-out at that concentration, not a potency): 79.2%
The estimate for compound 4 lay 2.8 percentage points above the measured number; the range from low to high includes it.
By their numbers in this assay, from the lowest: compounds 4, 1, 2 and 3 (each within the scatter of the next, the first and the last beyond it).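

In this assay, methoxycarbonyl in place of chloro on this aromatic carbon gives a number 3.1 percentage points lower from compound 1 to compound 4 (within the scatter), so four heavy atoms and two hydrogen-bond acceptors enter here without a step beyond the scatter. For the compounds shown here, this is the first reading at this position, since the earlier steps changed only the whole group on the thiocarbonyl carbon. No measurement available here explains the result.

Going by these compounds, whether a carboxylic acid or an amine on this aromatic carbon would give a step beyond the scatter remains open. A single-concentration read-out also leaves any difference in potency between the chloro and methoxycarbonyl compounds unresolved.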